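This account rests on a few compounds, and the source may have more. Where it says the series, first, only, none or still open, it means among the compounds named here.

Compound 1 `Cc1c(C=C(CO)CO)n(C)c(=O)[nH]c1=O`: in a functional assay on HeLa cells (Homo sapiens) for antiproliferative activity, read by MTT assay, with a stated time of 72 h (a higher number here means a weaker inhibitor, a lower number a stronger inhibitor), compound 1 gives > 100000 nM.
Compound 2 `COc1nc(CC(O)(CO)CO)c(C)c(OC)n1`: in this assay compound 2 gives > 100000 nM.
Compound 3 `COc1nc(CC(O)(COC(C)=O)COC(C)=O)c(C)c(OC)n1`: in this assay compound 3 gives > 100000 nM.

Each of these three readings is a limit of the assay and not a number. Compound 3 thus stands where every measured compound stands, at the limit of > 100000 nM in this assay, at which 3 of the 3 values shown sit. For the measured compounds named here, no numeric value separates any two of them, so no measured step is available to size a change.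

Compound 4 `COc1nc(CC(F)(COC(C)=O)COC(C)=O)c(C)c(OC)n1` differs from compound 3 by fluoro in place of hydroxy on a saturated chain carbon bound to three saturated chain carbons. With all three measured compounds at the limit, there is no basis in these data for expecting a step beyond the scatter in this assay in either direction. Compound 4 is therefore expected to give about 120000 nM, most probably reported again only as a limit, within a range from 40000 nM to 400000 nM. The step this estimate implies, a step that the limit leaves unreadable from compound 3 to compound 4, is expected to lie within the scatter.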

Compound 4, half-maximal inhibitory concentration: > 100000 nM
Compound 4 gave a limit, no number; the forecaster's own chance of this, stated with the estimate: 80%; the middle value does not contradict the limit.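

Compound 4 reads as a limit in this assay, as compound 3 does, so no step can be read from compound 3 to compound 4 for fluoro in place of hydroxy: the limit of > 100000 nM in this assay, at which 4 of the 4 values shown sit.

The compounds shown leave open whether any structural change here alters antiproliferative activity, since none gives a number.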